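Moving the ethyl group around the thiophene ring

This account rests on a few compounds, and the source may have more. Where it says the series, first, only, none or still open, it means among the compounds named here.

Measured compounds:
- Compound 1, `O=C(Nc1ccc(Cl)cc1)NS(=O)(=O)c1ccc(Cl)s1`, 58%
- Compound 2, `CCc1ccc(S(=O)(=O)NC(=O)Nc2ccc(Cl)cc2)s1`, 57%

Two ureas have been measured in a functional assay on the whole organism (6C3HED cells, Mus musculus) for inhibition, at a dose of 150 mg/kg by the oral route; a higher number here means more inhibition at the dose given (going by the name of the read-out), a lower number less inhibition. Compound 1 `O=C(Nc1ccc(Cl)cc1)NS(=O)(=O)c1ccc(Cl)s1` gives 58%, and compound 2 `CCc1ccc(S(=O)(=O)NC(=O)Nc2ccc(Cl)cc2)s1` gives 57%. Within the data shown here, the one step between them, a number 1 percentage points lower from compound 1 to compound 2 (within the scatter), lies within the scatter, so the two stand level and compound 2 is simply the lower of the two numbers, with compound 1 its nearest neighbour.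

Compound 3 `CCc1csc(S(=O)(=O)NC(=O)Nc2ccc(Cl)cc2)c1` differs from compound 2 by a group of 7 heavy atoms (6 carbon, 1 sulfur; one five-membered aromatic ring with 1 hetero atom) in place of a group of 7 heavy atoms (6 carbon, 1 sulfur; one five-membered aromatic ring with 1 hetero atom), on a sulfonyl sulfur. The two have the same atoms, joined differently: the five-membered aromatic ring with one hetero atom is re-attached to the sulfonyl sulfur at another carbon, and the ethyl group moves with it.

Among the measured compounds shown here, no measured step bears on this rearrangement directly. For the measured compounds named here, the only step known, a number 1 percentage points lower from compound 1 to compound 2 (within the scatter), exchanges a substituent on that ring without a shift beyond the scatter, and it says nothing about moving the attachment point. The inhibition of compound 3 in this assay is therefore expected to stay close to that of compound 2, with the step of a number 2 percentage points lower from compound 2 to compound 3 (within the scatter) estimated to lie within the scatter. Compound 3 is estimated at 55%, with a range from 35% to 75%.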

Compound 3, a percentage reported as inhibition, in the whole organism at one dose (the size of the read-out at that dose, not a potency): 55%
Compound 3: middle estimate and measured number agree at the digits printed; measured number inside the range.
By their numbers in this assay, from the lowest: compounds 3, 2 and 1 (each within the scatter of the next).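

In this assay, re-attaching the five-membered aromatic ring to the sulfonyl sulfur at another carbon, with the ethyl group moving along, leaves the read-out level (a number 2 percentage points lower from compound 2 to compound 3 (within the scatter)). The earlier step exchanged only a substituent on that ring, whereas this one shows that the 5-ethylthiophen-2-yl group can give way to its rearranged counterpart on the sulfonyl sulfur without a shift beyond the scatter. The rearranged compound also stands level with the chloro compound (a number 3 percentage points lower from compound 1 to compound 3 (within the scatter)), so all three sit within the scatter of one another, and no information is available on why the change in attachment leaves the inhibition level.

The compounds shown leave open whether this flat picture holds for other groups on the same ring, such as a longer chain like propyl, a methoxy group, an amine or a carboxylic acid, since chloro and ethyl are the only substituents compared there. They also leave open whether the three would still stand level at other doses, as each figure is the size of the inhibition at one oral dose and not a potency.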